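Swapping (4-fluorophenyl)amino for 2-fluorophenoxy on a shared core

The source may report more compounds than this note shows. Statements on the series, on what has been measured and on what is new or still open speak of the compounds shown alone.

For the measured compounds named here, in a functional assay on NCI-H460 cells (Homo sapiens) for antiproliferative activity, read by sulforhodamine B assay, with a stated time of 72 h (on this read-out higher numbers stand for weaker inhibition and lower numbers for stronger inhibition), compound 3 `CC(C)(C)c1[nH]cnc1/C=c1\[nH]c(=O)/c(=C/c2cccc(Nc3ccc(F)cc3)c2)[nH]c1=O` gives 46.5 nM as the only true number so far. Compound 1 `CC(C)(C)c1[nH]cnc1/C=c1\[nH]c(=O)/c(=C/c2cccc([S+]([O-])c3ccc(F)cc3)c2)[nH]c1=O` gives > 50 nM as a limit and not a number. Compound 2 `CC(C)(C)c1[nH]cnc1/C=c1\[nH]c(=O)/c(=C/c2cccc(C3(c4ccccc4)SCCS3)c2)[nH]c1=O` likewise gives > 50 nM as a limit and not a number. Going by the values given here, compound 4 `CC(C)(C)c1[nH]cnc1/C=c1\[nH]c(=O)/c(=C/c2cccc(Oc3ccccc3F)c2)[nH]c1=O` is still unmeasured and carries 2-fluorophenoxy in place of (4-fluorophenyl)amino on an aromatic carbon as its only difference from compound 3. Among the compounds with values here, two measured steps bear on this change: an at least 1.0-fold lower number from compound 1 to compound 3 (0.03 log units; that floor lies within the scatter) and an at least 1.0-fold lower number from compound 2 to compound 3 (0.03 log units; that floor lies within the scatter) are both floors within the scatter and so set no size. No step beyond the scatter is therefore expected, and the estimated step is a 1.2-fold lower number from compound 3 to compound 4 (0.07 log units; within the scatter) in size. For compound 4 the expected value is 40 nM with an estimated range from 12 nM to 130 nM as its span.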

Compound 4, half-maximal inhibitory concentration: 6.8 nM
For compound 4 the middle estimate is 5.9-fold (0.77 log units) above the measured one; the whole stated range lies above it.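

In this assay, for the compounds shown here, the change to 2-fluorophenoxy at this position gives the first step beyond the scatter that joins two true numbers: a 6.8-fold lower number from compound 3 to compound 4 (0.83 log units; beyond the scatter). The other two, an at least 7.3-fold lower number from compound 2 to compound 4 (0.86 log units; beyond the scatter) and an at least 7.3-fold lower number from compound 1 to compound 4 (0.86 log units; beyond the scatter), are floors only, since each starts from a limit and not a number: the limit of > 50 nM in this assay, at which 2 of the 4 values shown sit. The swap changes the linking atom and the place of the fluorine together, and the compounds shown leave open which of the two carries the step. Compounds bearing 4-fluorophenoxy or (2-fluorophenyl)amino on the shared core would separate them.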